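Aryl swap on the ring nitrogen: expectation for compound 3

The source may report more compounds than this note shows. Statements on the series, on what has been measured and on what is new or still open speak of the compounds shown alone.

Compound 1 `Nc1scc(CN2CCN(c3ccc(F)cc3Cl)CC2)c1C(=O)c1ccc(Cl)cc1` and compound 2 `Nc1scc(CN2CCN(c3cccc(F)c3F)CC2)c1C(=O)c1ccc(Cl)cc1` share one core and differ only in the group on the amine nitrogen in the ring. In an assay on CHO cells for displacement of a labelled ligand from adenosine receptor A3 (Homo sapiens), read by scintillation counting, with a stated time of 120 min, tested at 10 uM (a higher number here means more inhibition at the concentration tested (going by the name of the read-out), a lower number less inhibition), compound 1 gives 0%, and compound 2 gives 0%. Among the compounds with values here, the only step measured so far is no change at the digits printed from compound 1 to compound 2 (within the scatter). Compound 2 thus stands level with compound 1 at the digits shown, both at the floor of the read-out.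

Compound 3 `Nc1scc(CN2CCN(c3ccc(Cl)c(Cl)c3)CC2)c1C(=O)c1ccc(Cl)cc1` is the next member. The change 3,4-dichlorophenyl in place of 2,3-difluorophenyl on an amine nitrogen in a ring keeps the same place and the same count of heavy atoms, with chlorine in place of fluorine. Within the data shown here, the one measured step bears on it, since it too swapped one halogenated phenyl for another on the ring nitrogen, and that step was no change at the digits printed from compound 1 to compound 2 (within the scatter), flat. No movement beyond the scatter is therefore expected in this assay. The expected step here, no change at the digits printed from compound 2 to compound 3 (within the scatter), is flat. Compound 3 is estimated at 0%, with a range from 0% to 10%.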

Compound 3, a percentage reported as inhibition, at one concentration (the size of the read-out at that concentration, not a potency): 3%
Compound 3: the middle estimate sits 3 percentage points below what was measured, within the range that was stated.
By their numbers in this assay, from the lowest: compounds 1, 2 and 3 (each within the scatter of the next).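

In this assay, the 3,4-dichlorophenyl group on the ring nitrogen gives a number 3 percentage points higher from compound 2 to compound 3 (within the scatter) and a number 3 percentage points higher from compound 1 to compound 3 (within the scatter). This extends the flat reading from a pair of halogenated phenyl groups to a third group, one carrying chlorine alone, and compound 1, compound 2 and compound 3 all read alike at this position, with none going against that pattern. No measurement on hand accounts for this flat reading.

The compounds shown leave open whether any group on this nitrogen moves the read-out at all, for example a phenyl carrying a methoxy group or a carboxylic acid, or a benzyl group in place of the phenyl. They also leave open whether a change elsewhere on the shared core, such as an amide made from the free amine, would give a read-out that stands clear of the scatter.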